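Hydroxy to hydroxymethyl on the shared core: an estimate

This account rests on a few compounds, and the source may have more. Where it says the series, first, only, none or still open, it means among the compounds named here.

Compound 1 `CCCc1cc(O)cc(=O)n1Cc1ccc(-c2ccccc2-c2nn[nH]n2)cc1` gives 0.048 mg/kg in a functional assay on the whole organism with Rattus norvegicus as the target; a lower number here means that less compound is needed, a higher number that more compound is needed for the effect.
Compound 2 `CCCc1cc(S)cc(=O)n1Cc1ccc(-c2ccccc2-c2nn[nH]n2)cc1` gives 0.017 mg/kg.
Compound 3 `CCCc1cc(C(=O)O)cc(=O)n1Cc1ccc(-c2ccccc2-c2nn[nH]n2)cc1` gives 0.078 mg/kg.

Compound 1 stands second highest of these three numbers. Two measured steps lead away from it at the same aromatic carbon: a 1.6-fold higher number from compound 1 to compound 3 (0.21 log units; within the scatter), and a 2.8-fold lower number from compound 1 to compound 2 (0.45 log units; beyond the scatter). Compound 4 `CCCc1cc(CO)cc(=O)n1Cc1ccc(-c2ccccc2-c2nn[nH]n2)cc1` differs from compound 1 in one place: hydroxymethyl in place of hydroxy on an aromatic carbon. Among the compounds with values here, the two measured swaps at this carbon are the steps that bear on it; one stays within the scatter and the other is modest. A step beyond the scatter in this assay is therefore not expected. Compound 4 is estimated at 0.05 mg/kg, with a range from 0.02 mg/kg to 0.12 mg/kg. The expected step is then a 1.0-fold higher number from compound 1 to compound 4 (0.02 log units; within the scatter).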

Compound 4, dose for 50% inhibition: 0.3 mg/kg
Beside the measured number, compound 4's estimate is 6.0-fold (0.78 log units) below it, and the stated range ends below it.
By their numbers in this assay, from the lowest: compound 2; then compounds 1 and 3 (each within the scatter of the next); then compound 4.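

In this assay the steps of a 6.3-fold higher number from compound 1 to compound 4 (0.80 log units; beyond the scatter) and a 3.8-fold higher number from compound 3 to compound 4 (0.59 log units; beyond the scatter) and an 18-fold higher number from compound 2 to compound 4 (1.25 log units; beyond the scatter) all point the same way, leaving compound 4 with the highest number of the four. This aromatic carbon therefore responds clearly to hydroxymethyl, a group only one carbon larger than hydroxy. Keeping the same count of hydrogen-bond donors and acceptors did not keep the number, so those counts alone do not predict the result here.

Nothing available explains this rise. From the compounds shown here alone, whether an amine or a longer chain, such as hydroxyethyl, at this carbon would give a higher or lower number remains open.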